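Phenyl Brought Closer to the Carbonyl

The source may report more compounds than this note shows. Statements on the series, on what has been measured and on what is new or still open speak of the compounds shown alone.

The series shares one core, seen in compound 1 `O=C(CCCCCCCCc1ccccc1)N[C@H]1CCOC1=O`, and varies only the length of the saturated chain that carries the terminal phenyl. In a functional assay on PC-3 cells (Homo sapiens) for cytotoxicity, read by sulforhodamine B assay, with a stated time of 5 days (a higher number here means a weaker inhibitor, a lower number a stronger inhibitor), compound 1 gives 67000 nM. Compound 3 `O=C(CCCCCCCCCc1ccccc1)N[C@H]1CCOC1=O`, one chain carbon longer, gives 75000 nM in this assay. The step of a 1.1-fold higher number from compound 1 to compound 3 (0.05 log units; within the scatter) therefore leaves the two compounds within the scatter of each other, so neither can be called the more potent. Compound 2 `O=C(CCCCCCc1ccccc1)N[C@H]1CCOC1=O`, with the shortest chain of the three, reaches only the limit (the limit of > 100000 nM in this assay, at which 1 of the 3 values shown sits), reported as > 100000 nM.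

Compound 4 `O=C(CCCCCCCc1ccccc1)N[C@H]1CCOC1=O` is the next member to be measured. Its change from compound 3 is phenyl in place of phenethyl on a saturated chain carbon, seven bonds along the chain from a carbonyl carbon. The chain of compound 4 thus falls between those of compound 2 and compound 1. Within the data shown here, the one measured step, from compound 1 to compound 3, was within the scatter, while compound 2 gave only a limit; the data hold no measured step that shows a shortening of the chain. The expectation is that compound 4 lands near compound 1 or somewhat weaker, with a real chance that the assay again reports only a limit. Compound 4 is estimated at 90000 nM, between 50000 nM and 200000 nM, which would mean an expected step of a 1.2-fold higher number from compound 3 to compound 4 (0.08 log units; within the scatter).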

Compound 4, half-maximal inhibitory concentration: 85000 nM
For compound 4 the middle estimate is 1.1-fold (0.02 log units) above the measured one, within the range that was stated.
By their numbers in this assay, from the lowest: compounds 1, 3 and 4 (each within the scatter of the next). At a limit, above all of these: compound 2.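

Among these compounds, with phenyl in place of phenethyl, the step is a 1.1-fold higher number from compound 3 to compound 4 (0.05 log units; within the scatter), and with phenyl in place of benzyl it is a 1.3-fold higher number from compound 1 to compound 4 (0.10 log units; within the scatter), so this is the first measured shortening of the chain, and neither step stands clear of the scatter. The chains of compound 1, compound 3 and compound 4 therefore cannot be told apart in this assay, and compound 4 shows that a chain shorter than that of compound 1 can still give a number rather than a limit. The step of an at least 1.1-fold lower number from compound 2 to compound 4 (0.07 log units; that floor lies within the scatter) offers only a floor, and compound 2 remains the single limit in the series: the limit of > 100000 nM in this assay, at which 1 of the 4 values shown sits.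

The compounds shown leave open how far compound 2 truly lies from the other three, and so whether the chain length of compound 4 marks any real boundary. They also leave open whether an amine or a carboxylic acid in place of the terminal phenyl, or a much longer chain, would give a number that separates from this group.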